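Selenium Enters the Core: What to Expect of Compound 4

This account rests on a few compounds, and the source may have more. Where it says the series, first, only, none or still open, it means among the compounds named here.

Measured so far in a functional assay on PC-3 cells (Homo sapiens) for cytotoxicity, read by MTT assay, with a stated time of 72 h; a higher number here means that more compound is tolerated, a lower number that less compound is tolerated:
compound 1 `C[Se]/C(=N\C(=O)c1cc2ccccc2s1)NC(=O)c1cc2ccccc2s1`, 94000 nM
compound 2 `CS/C(=N\C(=O)c1ccno1)NC(=O)c1ccno1`, a limit of the assay, > 100000 nM
compound 3 `C[Se]/C(=N\C(=O)c1cccs1)NC(=O)c1cccs1`, a limit of the assay, > 100000 nM

Compound 2 stands at the limit of this assay, which it shares with compound 3 (the limit of > 100000 nM in this assay, at which 2 of the 3 values shown sit); only compound 1 gives a number. Going by the values given here, no step between two measured compounds changes a single group, so no measured step guides the next one.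

Compound 4 `O=C(/N=C(/NC(=O)c1ccno1)[Se]Cc1ccccc1)c1ccno1` differs from compound 2 by a group of 8 heavy atoms (7 carbon, 1 selenium; one six-membered aromatic ring of carbon only) in place of a group of 2 heavy atoms (1 carbon, 1 sulfur; no ring), on a carbon with a double bond to nitrogen. For this assay compound 4 is expected to be tolerated at about 80000 nM, with a likely range from 30000 nM to 150000 nM, the expected step of an at least 1.2-fold lower number from compound 2 to compound 4 (0.09 log units; that floor lies within the scatter) remaining close to what the limit of compound 2 allows.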

Compound 4, concentration lethal to 50% of the cells: > 100000 nM
Compound 4: only a limit was reported; the forecaster's own chance of this, stated with the estimate: 45%; middle value at least 1.2-fold (0.09 log units) from the limit.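

In this assay, going by these compounds alone, compound 4 gives > 100000 nM, a limit of the assay, and compound 2 also stands at a limit, so no step between them can be read. The compounds shown leave open whether replacing methylsulfanyl with the selenium group carrying the six-membered aromatic ring changes the concentration tolerated at all.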